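This account rests on a few compounds, and the source may have more. Where it says the series, first, only, none or still open, it means among the compounds named here.

Compound 1 `COc1ccc(CN(C)C(=O)c2ccc(-c3cc(-c4cc(OC)ccc4OC)no3)s2)cc1` gives in a functional assay on PC-3 cells (Homo sapiens) for cytotoxicity, read by XTT assay, with a stated time of 72 h (on this read-out lower numbers stand for stronger inhibition and higher numbers for weaker inhibition), a reading of > 30000 nM, which is a limit of the assay and not a number.
Compound 2 `CCCN(C)C(=O)c1ccc(-c2cc(-c3cc(OC)ccc3OC)no2)s1` gives in this assay > 30000 nM, again a limit.
Compound 3 `COc1ccc(OC)c(-c2cc(-c3ccc(C(=O)NCC4CC4)s3)on2)c1` gives in this assay > 30000 nM, also a limit.

Compound 3 therefore stands nowhere on a scale of numbers: its value is a limit, and the other two values shown are limits as well, so no ordering among compounds 1, 2 and 3 can be read. The steps among them, a step that the two limits leave unreadable from compound 1 to compound 2, a step that the two limits leave unreadable from compound 1 to compound 3 and a step that the two limits leave unreadable from compound 2 to compound 3, are all left unreadable by the limits, as all three values sit at the limit of > 30000 nM in this assay, at which 3 of the 3 values shown sit.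

Compound 4 `CCN(CC)C(=O)c1ccc(-c2cc(-c3cc(OC)ccc3OC)no2)s1` differs from compound 3 in one place: diethylamino in place of (cyclopropylmethyl)amino on a carbonyl carbon. All measured steps that bear on this position, among them a step that the two limits leave unreadable from compound 2 to compound 3, are unreadable in size, so no direction beyond the scatter can be expected from them. Compound 4 is expected to remain at or near the same limit, with the step that the limit leaves unreadable from compound 3 to compound 4 estimated as essentially none. The estimate for compound 4 in this assay is 40000 nM, expected to lie between 15000 nM and 120000 nM.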

Compound 4, half-maximal inhibitory concentration: > 30000 nM
Compound 4: a limit, no number; the forecaster's own chance of this, stated with the estimate: 85%; the middle value does not contradict the limit.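

No new step can be read: compound 4, like compounds 1, 2 and 3, gives only a limit and not a number in this assay, so every step among them stays unreadable: the limit of > 30000 nM in this assay, at which 4 of the 4 values shown sit.

The compounds shown leave open whether the different amino groups on the carbonyl carbon differ in effect at all.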